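A few compounds are considered here, and "the series" means these few. Any claim that something is new, unique, unknown or untested is made for them only; others in the source may bear on it.

Two compounds carry the same kind of triazene chain attached to a heterocyclic core. Compound 1 is `CCCCCN(C)/N=N/c1nc[nH]c1C(N)=O`, and compound 2 is `COC(=O)c1c[nH]nc1/N=N/N(C)C`. In a functional assay on L1210 cells (Mus musculus) for antiproliferative activity (on this read-out higher numbers stand for higher potency (the scale is a negative logarithm) and lower numbers for lower potency), compound 1 gives 3.58, which is the higher of the two numbers; compound 2 gives 3.49, and the gap between them lies within the usual scatter, so the two are not distinguishable on this read-out.

The step considered here leads from compound 1 to compound 3, whose structure is `CCCN(C)/N=N/c1nc[nH]c1C(N)=O`. The difference is hydrogen in place of ethyl on a saturated chain carbon, three bonds along the chain from an amine nitrogen. The chain on the amine nitrogen becomes shorter, with nothing else in the molecule altered.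

Among the compounds with values here, with no measured pair of this kind to lean on, there is no basis for expecting a large shift in either direction; the expectation is for a step of about a number 0.08 log units lower from compound 1 to compound 3 (within the scatter), that is, nothing beyond the scatter. Compound 3 is therefore estimated at 3.5 in this assay, with a range from 3 to 4.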

Compound 3, logarithm of the reciprocal of the active concentration, log(1/C): 3.58
Estimate against measurement, compound 3: 0.08 log units below; the range from low to high includes it.
By their numbers in this assay, from the lowest: compounds 2, 1 and 3 (each within the scatter of the next).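

Within the data shown here, this is the first pair here that differs in only one place, so it is the first direct reading of what the length of this chain does. In this assay, cutting the pentyl chain on the amine nitrogen back to propyl gives no change at the digits printed from compound 1 to compound 3 (within the scatter). This one pair therefore shows that, on this core, the ethyl end of the chain can give way to hydrogen, at a saturated chain carbon three bonds along from the amine nitrogen, without a shift that stands out from the scatter; nothing available explains why the number holds.

A single pair cannot show whether the chain length matters anywhere else, so it sets no trend: a longer chain such as octyl could still behave differently. The same holds for a chain that ends in something other than plain carbon, such as an amine or a carboxylic acid, and for the same shortening made on a different core.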